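Propyl Capping of a Thiol in Two Related Cores

This account rests on a few compounds, and the source may have more. Where it says the series, first, only, none or still open, it means among the compounds named here.

compound 1 `O[C@@H]1[C@@H](O)[C@H](Oc2cccc3cccc(S)c23)OC[C@H]1O`: 45 uM
compound 2 `O[C@@H]1[C@@H](O)[C@H](Oc2ccc3ccc(S)cc3c2)OC[C@H]1O`: 360 uM
compound 3 `CCCSc1cccc2cccc(O[C@@H]3OC[C@@H](O)[C@H](O)[C@H]3O)c12`: 155 uM

Three compounds were measured in a functional assay on T-24 cells (Homo sapiens) for antiproliferative activity, read by crystal violet staining, with a stated time of 96 h; on this read-out lower numbers stand for an effect already at smaller amounts and higher numbers for an effect only at larger amounts of compound. Compound 1 and compound 2 share the same atoms joined differently; the difference between the two cores is not broken down here. In this assay compound 2 gives 360 uM, the highest of the three numbers, whereas compound 1 gives 45 uM and compound 3 gives 155 uM. Compound 3 arises from compound 1 by propyl in place of hydrogen on a sulfur, and that step is a 3.4-fold higher number from compound 1 to compound 3 (0.54 log units; beyond the scatter). Compound 4 `CCCSc1ccc2ccc(O[C@@H]3OC[C@@H](O)[C@H](O)[C@H]3O)cc2c1` carries the same change on the core of compound 2: propyl in place of hydrogen on a sulfur. Within the data shown here, a step of similar size is expected, a 2.8-fold higher number from compound 2 to compound 4 (0.44 log units; beyond the scatter), because the step of a 3.4-fold higher number from compound 1 to compound 3 (0.54 log units; beyond the scatter) is the only measured example of this change. Compound 4 is therefore estimated at 1000 uM, within a range from 350 uM to 3000 uM, with a fair chance that the assay reports only a limit.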

Compound 4, concentration for half-maximal effect: 60 uM
The estimate for compound 4 lay 17-fold (1.22 log units) above the measured number; measured number below the stated range.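

In this assay, propyl in place of hydrogen on a sulfur gives a 6.0-fold lower number from compound 2 to compound 4 (0.78 log units; beyond the scatter). The change therefore did not carry over in direction from the core of compound 1 to the core of compound 2: the same change on two cores in this assay, a 3.4-fold higher number (0.54 log units; beyond the scatter) from compound 1 to compound 3 and a 6.0-fold lower number (0.78 log units; beyond the scatter) from compound 2 to compound 4, 21-fold (1.32 log units) apart, beyond the scatter of two such steps. This shows that, for these two pairs, the outcome of the change depends on the core, but with one pair per core it does not show why the cores differ or how a further core would respond.

The compounds shown leave open whether ethyl or a longer chain such as butyl on the sulfur would follow the propyl result on either core. As far as these compounds go, how an amine or a carboxylic acid in that place would behave also remains open.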